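The source may report more compounds than this note shows. Statements on the series, on what has been measured and on what is new or still open speak of the compounds shown alone.

Compound 1, `Cc1ccc(Nc2nc(C)c(C(=O)/C=C/c3ccc(Cl)cc3)s2)cc1`, gives > 25000 nM in a functional assay on Bel-7402 cells (Homo sapiens) for cytotoxicity, read by MTT assay (a lower number here means a stronger inhibitor, a higher number a weaker inhibitor), which is a limit of the assay and not a number.
Compound 2, `Cc1ccc(Nc2nc(C)c(C(=O)/C=C/c3ccccc3)s2)cc1`, gives > 25000 nM in this assay; this too is a limit.
Compound 3, `COc1cccc(/C=C/C(=O)c2sc(Nc3ccccc3)nc2C)c1`, gives > 25000 nM in this assay, again a limit.

All three measured compounds share one core and differ only in the groups on their two outer rings. Compound 3 therefore stands at the limit of this assay, exactly where the two others stand: the limit of > 25000 nM in this assay, at which 3 of the 3 values shown sit. Going by the values given here, the single step among them that changes one place, a step that the two limits leave unreadable from compound 1 to compound 2, cannot be read, since both of its ends are limits.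

Compound 4, `COc1cccc(/C=C/C(=O)c2sc(Nc3ccc(C)cc3)nc2C)c1`, is the next compound. It differs from compound 3 by methyl in place of hydrogen on an aromatic carbon. Among the compounds with values here, no measured step gives the size of this change in this assay, and the one step on record, a step that the two limits leave unreadable from compound 1 to compound 2, is unreadable. Because (the limit of > 25000 nM in this assay, at which 3 of the 3 values shown sit), there is nothing in the measured set that points to a number below the limit, and compound 4 is expected to remain at the limit as well, an expected step that the limit leaves unreadable from compound 3 to compound 4. The estimate for compound 4 is 40000 nM, within 12000 nM to 150000 nM.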

Compound 4, half-maximal inhibitory concentration: > 25000 nM
Compound 4 ended at the assay's limit; the forecaster's own chance of this, stated with the estimate: 85%; the middle value is on the limit's open side.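

In this assay compound 4 gives > 25000 nM and this is a limit, not a number. Its steps from compound 1, compound 2 and compound 3 therefore cannot be read, and all four compounds stand at the same place: the limit of > 25000 nM in this assay, at which 4 of the 4 values shown sit.

The compounds shown leave open whether any change on the two outer rings brings a measurable value in this assay, and how large such a step would be.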